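Where compound 3 stands before a change on the carbonyl carbon

The compounds below may be only part of what the source reports. "The series", "measured", "known", "first", "only" and "open" are said of these compounds alone.

Three compounds share a core in which an amide and a sulfonamide hang from the two ends of the same scaffold. Compound 1 `Cc1ccc(S(=O)(=O)NCc2ccc(CNC(=O)c3ccc([N+](=O)[O-])cc3)cc2)cc1` gives 10 nM in an assay on MDA-MB-231 cells for binding affinity to C-X-C chemokine receptor type 4 (Homo sapiens), read by immunofluorescence and microscopy, with stated times of 10 min and 30 min; on this read-out higher numbers stand for an effect only at larger amounts of compound and lower numbers for an effect already at smaller amounts. Compound 2 `COc1ccccc1C(=O)NCc1ccc(CNS(=O)(=O)c2ccc(C)cc2)cc1` gives 100 nM in this assay, and the change is a 10-fold higher number from compound 1 to compound 2 (1.00 log units; beyond the scatter). Compound 3 `COc1ccccc1C(=O)NCc1ccc(CNS(=O)(=O)c2ccccc2)cc1` gives 1 nM in this assay, after a 100-fold lower number from compound 2 to compound 3 (2.00 log units; beyond the scatter). Compound 3 thus holds the lowest number of the three, with compound 1 nearest and compound 2 furthest, both differences beyond the scatter.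

Compound 4 `O=C(NCc1ccc(CNS(=O)(=O)c2ccccc2)cc1)c1cccc(F)c1` has not yet been measured. It differs from compound 3 in one place:
3-fluorophenyl in place of 2-methoxyphenyl on a carbonyl carbon
Going by the values given here, only one measured step touches the group on the carbonyl carbon: a 10-fold higher number from compound 1 to compound 2 (1.00 log units; beyond the scatter), a modest shift. The large step of a 100-fold lower number from compound 2 to compound 3 (2.00 log units; beyond the scatter) sits on the sulfonyl side and says nothing directly about this exchange. Since the one comparable change moved the number modestly, and since compound 3 already holds the lowest number shown, a modest rise in this assay is expected for compound 4, estimated as a 3.0-fold higher number from compound 3 to compound 4 (0.48 log units; beyond the scatter). Compound 4 is therefore expected to give about 3 nM in this assay, with a range from 0.3 nM to 30 nM.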

Compound 4, effective concentration (reported as EC, without a stated level of effect): 100 nM
Compound 4: middle estimate off by 33-fold (1.52 log units), on the low side, and the stated range ends below it.
By their numbers in this assay, from the lowest: compound 3; then compound 1; then compounds 2 and 4 (each within the scatter of the next).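

In this assay, going by these compounds alone, the exchange on the carbonyl carbon gives a 100-fold higher number from compound 3 to compound 4 (2.00 log units; beyond the scatter), a large step, whereas the only earlier step at this place, a 10-fold higher number from compound 1 to compound 2 (1.00 log units; beyond the scatter), was modest. The group on the carbonyl carbon can therefore shift the number by as much as the change on the sulfonyl side did in a 100-fold lower number from compound 2 to compound 3 (2.00 log units; beyond the scatter), and the low number of compound 3 does not survive replacing its 2-methoxyphenyl with 3-fluorophenyl, an exchange in which 1 hydrogen-bond acceptor gives way to 0. Nothing available accounts for the size of this step.

Because this exchange alters both the substituent and its place on the ring, the compounds shown cannot tell which of the two matters, and plain phenyl on the carbonyl carbon would offer a reference that is missing from this set. Going by these compounds, it also remains open whether the step would keep its size with the methyl group on the sulfonyl side, and how an amine or a carboxylic acid on the ring at this place would read out.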